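This account rests on a few compounds, and the source may have more. Where it says the series, first, only, none or still open, it means among the compounds named here.

Measured compounds:
Compound 1 `COc1ccc(C2=C(c3cc(OC)c(OC)c(OC)c3)C(=O)CC2O[SiH2]C(C)(C)C)cc1` — in an ADME assay on L132 cells (Homo sapiens) for cytotoxicity, read by MTT assay, with a stated time of 72 h (a lower number here means a stronger inhibitor, a higher number a weaker inhibitor), compound 1 gives > 100 ug/mL, which is a limit of the assay rather than a number.
Compound 2 `COc1ccc(OC)c(C2=C(c3cc(OC)c(OC)c(OC)c3)C(=O)CC2O[SiH2]C(C)(C)C)c1` — in this assay compound 2 gives 100 ug/mL.
Compound 3 `COc1ccc(C2=C(c3cc(OC)c(OC)c(OC)c3)C(=O)CC2O)cc1` — in this assay compound 3 gives 10 ug/mL.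

Compound 3 differs from compound 1 by a hydrogen atom in place of a group of 5 heavy atoms (4 carbon, 1 silicon; no ring), on an oxygen on a saturated carbon. From the compounds shown here alone, that change produced an at least 10-fold lower number from compound 1 to compound 3 (1.00 log units; beyond the scatter); its full size stays open because the limit of > 100 ug/mL in this assay, at which 1 of the 3 values shown sits, sets the starting point as a limit only. The cores of compound 1 and compound 2 differ by 2,5-dimethoxyphenyl in place of 4-methoxyphenyl on a double-bonded ring carbon, a change that gave a number no higher from compound 1 to compound 2 (the limit leaves the size open).

Compound 4 `COc1ccc(OC)c(C2=C(c3cc(OC)c(OC)c(OC)c3)C(=O)CC2O)c1` has not yet been measured. It differs from compound 2 by a hydrogen atom in place of a group of 5 heavy atoms (4 carbon, 1 silicon; no ring), on an oxygen on a saturated carbon, the same change as that from compound 1 to compound 3, in the same place. Against the core of compound 2, this change is expected to give a 10-fold lower number from compound 2 to compound 4 (1.00 log units; beyond the scatter), resting on the step from compound 1 to compound 3 of an at least 10-fold lower number from compound 1 to compound 3 (1.00 log units; beyond the scatter) and on compound 2 standing at 100 ug/mL. Compound 4 is therefore estimated at 10 ug/mL, with the expected range running from 3 ug/mL to 30 ug/mL.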

Compound 4, half-maximal inhibitory concentration: > 100 ug/mL
Compound 4 gave a limit, no number; the forecaster's own chance of this, stated with the estimate: 5%; at least 10-fold (1.00 log units) between middle value and limit.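

The exchange of the group of 5 heavy atoms (4 carbon, 1 silicon) for a hydrogen atom on the oxygen did not carry from one core to the other in this series: the same change on two cores in this assay, an at least 10-fold lower number (1.00 log units; beyond the scatter) from compound 1 to compound 3 and a number no lower (the limit leaves the size open) from compound 2 to compound 4, at least 10-fold (1.00 log units) apart, beyond the scatter of two such steps

In this assay compound 4 gives > 100 ug/mL, which is a limit of the assay and not a number. The new step reads as a number no lower from compound 2 to compound 4 (the limit leaves the size open), so it shows neither how large the change is on this core nor why the two cores part, and the comparison rests on one pair of steps, partly at the edge of the measurable range: the limit of > 100 ug/mL in this assay, at which 2 of the 4 values shown sit.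

The compounds shown leave open how the cores of compound 1 and compound 2 compare with other groups on that oxygen, such as a methyl ether or an acetyl ester. They also leave open whether an amine in place of that oxygen would follow either core.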